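Adding an Acetyl Group to Compound 2

This account rests on a few compounds, and the source may have more. Where it says the series, first, only, none or still open, it means among the compounds named here.

Measured so far in a functional assay on U-87MG ATCC cells for cytotoxicity against U-87 MG (Homo sapiens), read by colorimetric assay and MTT assay; a higher number here means a weaker inhibitor, a lower number a stronger inhibitor:
compound 1 `COc1cc(OC)c2cc(-c3ccccc3)c(O)nc2c1` gives 10000 nM
compound 2 `COc1cc(OC)c2cc(-c3ccc(O)cc3)c(=O)n(C)c2c1` gives 10000 nM

Compound 2 stands level with compound 1 at the digits shown, so this pair offers no difference in strength to interpret. The next compound keeps the shared core of compound 2 and alters one spot. Compound 3 `COc1cc(OC)c2cc(-c3ccc(OC(C)=O)cc3)c(=O)n(C)c2c1` differs from compound 2 as follows: acetyl in place of hydrogen on an oxygen on an aromatic ring. Put simply, acetyl takes the place of hydrogen on an oxygen on an aromatic ring, which turns hydroxy into acetoxy.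

For the measured compounds named here, no measured pair differs in only one place, so the data give no direct guide to the effect of this change. The only anchors are the two values themselves: compound 1 gives 10000 nM, and compound 2 gives 10000 nM. On that thin basis, no step beyond the scatter is expected in this assay, and no direction is favoured. The estimated change is a 1.1-fold lower number from compound 2 to compound 3 (0.05 log units; within the scatter). For compound 3 the expected value is 9000 nM, with an estimated range of 3000 nM to 15000 nM.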

Compound 3, half-maximal inhibitory concentration: 10000 nM
The estimate for compound 3 lay 1.1-fold (0.05 log units) below the measured number; the range from low to high includes it.
By their numbers in this assay, from the lowest: compounds 1, 2 and 3 (each within the scatter of the next).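

In this assay, putting acetyl in place of hydrogen on an oxygen on an aromatic ring, which turns hydroxy into acetoxy, gives no change at the digits printed from compound 2 to compound 3 (within the scatter). This is the only pair shown that differs in one place, so it offers the first direct reading of this position: here, the swap from hydroxy to acetoxy leaves the number in this assay unmoved, with compound 3 at 10000 nM. No supporting measurement bears on this result, so it records what happened and offers no explanation.

One flat step covers only one replacement at this oxygen, and it does not show whether any change here can move the number at all. Still open, going by these compounds, is whether a longer chain in place of the acetyl, or an amine or a carboxylic acid carried at this same place on the shared core, would shift the value in this assay in either direction, or leave it where compound 2 and compound 3 stand.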